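The source may report more compounds than this note shows. Statements on the series, on what has been measured and on what is new or still open speak of the compounds shown alone.

Measured so far in a functional assay on RAW264.7 cells (Mus musculus) for inhibition, read by Griess assay, with a stated time of 24 h; on this read-out higher numbers stand for weaker inhibition and lower numbers for stronger inhibition:
- compound 1 `COC1=CC2(C=C(OC)C1=O)[C@@H](CO)[C@H](c1ccc(O)c(OC)c1)O[C@H]2[C@H](O)CO`: 5600 nM
- compound 2 `COC1=CC2(C=C(OC)C1=O)[C@H](CO)[C@@H](c1ccc(O)c(OC)c1)O[C@@H]2[C@@H](O)CO`: 17900 nM

Of these two, compound 1 has the lower number and is therefore the stronger inhibitor in this assay. The next compound, compound 3 `COC1=CC2(C=C(OC)C1=O)[C@@H](CO)[C@H](c1cc(OC)c(O)c(OC)c1)O[C@H]2[C@H](O)CO`, keeps the core and configuration of compound 1 and changes in one place: methoxy in place of hydrogen on an aromatic carbon. In words, a methoxy takes the place of a hydrogen on an aromatic carbon.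

Within the data shown here, only one measured step exists, a 3.2-fold higher number from compound 1 to compound 2 (0.50 log units; beyond the scatter), and it is modest. It bears on this change only loosely, as the fact that compounds 1 and 2 differ only in the configuration as drawn shows that it concerns configuration alone. Among the measured compounds shown here, no measured step adds a group, so the value of compound 1, 5600 nM, remains the best anchor, and no clear direction can be expected. The expected result is a 1.1-fold higher number from compound 1 to compound 3 (0.03 log units; within the scatter), meaning no step beyond the scatter. For compound 3 the estimated value is 6000 nM, with an expected range from 2200 nM to 16000 nM.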

Compound 3, half-maximal inhibitory concentration: 4300 nM
The estimate for compound 3 lay 1.4-fold (0.14 log units) above the measured number, and the stated range covers the measured number.
By their numbers in this assay, from the lowest: compounds 3 and 1 (each within the scatter of the next); then compound 2.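

In this assay, placing a methoxy on this aromatic carbon, ortho to a hydroxy group, gives a 1.3-fold lower number from compound 1 to compound 3 (0.11 log units; within the scatter), so the two compounds cannot be told apart. The earlier pair differed only in configuration and said nothing about the aromatic ring, whereas this result shows that the ring carbon can carry a methoxy without a step beyond the scatter. Nothing available explains why this change leaves the number within the scatter.

The compounds shown leave open whether a larger group at this carbon, such as a longer ether chain, or a group of another kind, such as an amine or a carboxylic acid, would also stay within the scatter. They also leave open whether a methoxy here would behave in the same way on the mirror-image framework of compound 2.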